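This account rests on a few compounds, and the source may have more. Where it says the series, first, only, none or still open, it means among the compounds named here.

In an ADME assay on HEK293 cells (Homo sapiens) for inhibition, read by MTT assay, with a stated time of 48 h, tested at 25 uM (on this read-out lower numbers stand for less inhibition and higher numbers for more inhibition at the one concentration tested (going by the name of the read-out)), compound 1 `COc1ccccc1-n1cc(COc2ccc3c(c2)CCC3)nn1` gives 19.8%. Compound 2 `Brc1ccc(-n2cc(COc3ccc4c(c3)CCC4)nn2)cc1` carries a 4-bromophenyl on the same aromatic nitrogen, but in this assay compound 2 gives "not determined" (no result reported), so compound 2 stands nowhere on the scale. The step to compound 3 `COc1cccc(-n2cc(COc3ccc4c(c3)CCC4)nn2)c1` is 3-methoxyphenyl in place of 4-bromophenyl on an aromatic nitrogen. With no value for compound 2, the size of that step in this assay cannot be read from the data; since compound 1 and compound 3 differ only in where the methoxy group sits, a step from compound 2 is expected to land in the same region, with no direction that can be stated. Compound 3 is expected to give 20% in this assay, estimated between 5% and 40%.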

Compound 3, a percentage reported as inhibition, at one concentration (the size of the read-out at that concentration, not a potency): 25.8%
Compound 3: middle estimate off by 5.8 percentage points, on the low side; measured number inside the range.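

In this assay, 3-methoxyphenyl in place of 2-methoxyphenyl on the aromatic nitrogen gives a number 6 percentage points higher from compound 1 to compound 3 (within the scatter) and so does not separate these two methoxyphenyl groups at this position. The step from compound 2 to compound 3 cannot be read, since compound 2 has no number. No measured evidence bears on the cause of this result.

From the compounds shown here alone, whether 4-bromophenyl gives a similar read-out stays open. So does the effect of a different kind of group on this phenyl ring, such as an amine or a carboxylic acid.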